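Phenoxybenzylidene thiosemicarbazide series: lipophilicity notes

The compounds below may be only part of what the source reports. "The series", "measured", "known", "first", "only" and "open" are said of these compounds alone.

Measured so far:
compound 1 `O=[N+]([O-])c1ccc(Oc2ccc(/C=N/NC(=S)Nc3ccccc3)cc2)cc1` gives 4.95 in a physicochemical assay for lipophilicity, in phosphate buffer, measured as octanol-water partition, with a stated time of 24 h; a higher number here means a more lipophilic compound, a lower number a more polar compound.
compound 2 `Cc1ccc(Oc2ccc(/C=N/NC(=S)Nc3ccccc3)cc2)cc1` gives 5.39 in this assay.
compound 3 `Cc1cc(Oc2ccc(/C=N/NC(=S)Nc3ccccc3)cc2)ccc1Cl` gives 6.03 in this assay.

Compound 1 holds the lowest of the three numbers. Its nearest neighbour is compound 2, reached by a number 0.44 log units higher from compound 1 to compound 2 (beyond the scatter) (methyl in place of nitro on an aromatic carbon). The furthest is compound 3, reached by a number 1.08 log units higher from compound 1 to compound 3 (beyond the scatter); compound 3 is also set apart from compound 2 by a number 0.64 log units higher from compound 2 to compound 3 (beyond the scatter).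

The next compound, compound 4 `O=[N+]([O-])c1ccc(Oc2ccc(/C=N/NC(=S)Nc3ccc(Cl)cc3)cc2)cc1`, differs from compound 1 by chloro in place of hydrogen on an aromatic carbon. Within the data shown here, no measured step is the same change, but the step from compound 2 to compound 3 carries a chloro entering on an aromatic carbon alongside a methyl, and it was a modest rise, larger than the rise from compound 1 to compound 2. A modest rise in this assay beyond the scatter is therefore expected for compound 4, estimated as a number 0.60 log units higher from compound 1 to compound 4 (beyond the scatter) because the step of a number 0.64 log units higher from compound 2 to compound 3 (beyond the scatter) gives the closest measured precedent.

Compound 4 is expected at 5.55, with a range of 5.25 to 5.9.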

Compound 4, partition coefficient: 5.52
For compound 4 the middle estimate is 0.03 log units above the measured one; low and high end bracket the measured number.
By their numbers in this assay, from the lowest: compound 1; then compounds 2 and 4 (each within the scatter of the next); then compound 3.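

Among these compounds, this is the first change on the anilino end of the molecule: every earlier step altered the ring on oxygen, while the terminal phenyl stayed the same. In this assay, phenyl to 4-chlorophenyl, para to a large group, gives a number 0.57 log units higher from compound 1 to compound 4 (beyond the scatter) and so shows that this position also moves the read-out, with the nitro group left in place. Among the compounds shown here, it also gives the series a step in which chloro is the only change, whereas the earlier chloro entered together with a methyl in the step to compound 3. No available measurement explains the rise.

Whether the same chloro step holds on compound 2 or compound 3, where the ring on oxygen carries methyl or 4-chloro-3-methyl instead of nitro, stays open, as the compounds shown offer one such pair only. Also open, from the compounds shown here alone, is how this position reads with a different group on the same aromatic carbon, such as an amine, a carboxylic acid or a methoxy group, so one chloro gives a single point and no trend for this position.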